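The compounds below may be only part of what the source reports. "The series", "measured", "known", "first", "only" and "open" are said of these compounds alone.

Measured so far in an assay on CHO cells for displacement of a labelled ligand from adenosine receptor A1 (Homo sapiens), tested at 10 uM; on this read-out higher numbers stand for more inhibition at the one concentration tested (going by the name of the read-out) and lower numbers for less inhibition:
- compound 1 `O=C(Nc1ccc(Cl)cc1)Nc1nn(-c2ccccc2)c(=O)c2ccccc12` gives 10%
- compound 2 `COc1ccc(OC)c(NC(=O)Nc2nn(-c3ccccc3)c(=O)c3ccccc23)c1` gives 0%
- compound 3 `Cc1ccccc1NC(=O)Nc1nn(-c2ccccc2)c(=O)c2ccccc12` gives 20%

On these numbers compound 1 is separated from each of the others only within the scatter: a number 10 percentage points lower from compound 1 to compound 2 (within the scatter) and a number 10 percentage points higher from compound 1 to compound 3 (within the scatter). Among the measured compounds shown here, the single step beyond the scatter, a number 20 percentage points higher from compound 2 to compound 3 (beyond the scatter), does not start from compound 1.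

Compound 4 `O=C(Nc1ccccc1Cl)Nc1nn(-c2ccccc2)c(=O)c2ccccc12` is the next case; relative to compound 1 the change is 2-chlorophenyl in place of 4-chlorophenyl on an amide-type nitrogen. The two measured steps from compound 1 also exchange the 4-chlorophenyl on the amide-type nitrogen and both stay within the scatter, so in this assay the expected step is a number 5 percentage points higher from compound 1 to compound 4 (within the scatter), no clear direction. The estimate for compound 4 is 15%, expected between 0% and 35%.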

Compound 4, a percentage reported as inhibition, at one concentration (the size of the read-out at that concentration, not a potency): 0%
Compound 4: the middle estimate sits 15 percentage points above what was measured; the range from low to high includes it.
By their numbers in this assay, from the lowest: compounds 2, 4, 1 and 3 (each within the scatter of the next, the first and the last beyond it).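

In this assay, 2-chlorophenyl in place of 4-chlorophenyl on the amide-type nitrogen gives no readable shift (a number 10 percentage points lower from compound 1 to compound 4 (within the scatter)). Chloro in place of methyl on an aromatic carbon gives the first step beyond the scatter that exchanges only one substituent on this aryl group (a number 20 percentage points lower from compound 3 to compound 4 (beyond the scatter)). 2-Chlorophenyl in place of 2,5-dimethoxyphenyl leaves the number unchanged (no change at the digits printed from compound 2 to compound 4 (within the scatter)).

On these data alone, whether an amine or a carboxylic acid on this phenyl ring would raise the inhibition remains open. No supporting data explain the chloro and methyl difference.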